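Fluoro to trifluoromethyl on the phenoxy ring, second core

The source may report more compounds than this note shows. Statements on the series, on what has been measured and on what is new or still open speak of the compounds shown alone.

Measured so far in an assay on cells for inhibition of Voltage-dependent T-type calcium channel subunit alpha-1H (Homo sapiens), read by FLIPR and calcium flux, with stated times of 600 s and 300 s; a lower number here means a stronger inhibitor, a higher number a weaker inhibitor:
- compound 1, `CN(Cc1ccc(OCCCN)cc1)c1nc2ccc(Oc3ccc(C(F)(F)F)cc3)cc2s1`, gives 248000 nM
- compound 2, `CN(Cc1ccc(OCCCN)cc1)c1nc2ccc(Oc3ccc(F)cc3)cc2s1`, gives 492000 nM
- compound 3, `N=C(N)NCCCOc1ccc(CNc2nc3ccc(Oc4ccc(F)cc4)cc3s2)cc1`, gives 288000 nM

All three numbers are weak and lie close together. For the measured compounds named here, the one change made twice in the set is trifluoromethyl in place of fluoro on an aromatic carbon. Measured once, it gave a 2.0-fold lower number from compound 2 to compound 1 (0.30 log units; within the scatter), a step that stays inside the usual scatter and so cannot be read as a real gain.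

Compound 3 carries a different core from compound 2; the difference between the two cores is not broken down here. Compound 4, `N=C(N)NCCCOc1ccc(CNc2nc3ccc(Oc4ccc(C(F)(F)F)cc4)cc3s2)cc1`, has not been measured. Going by the values given here, it differs from compound 3 by trifluoromethyl in place of fluoro on an aromatic carbon, which is the same change, at the same place, as the one from compound 2 to compound 1.

Resting on a 2.0-fold lower number from compound 2 to compound 1 (0.30 log units; within the scatter), the expected step is a 1.7-fold lower number from compound 3 to compound 4 (0.23 log units; within the scatter), with wide room in either direction since a single step of that size is not distinguishable from scatter. Compound 4 is estimated at 170000 nM, between 60000 nM and 450000 nM.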

Compound 4, half-maximal inhibitory concentration: 195000 nM
Compound 4: the middle estimate sits 1.1-fold (0.06 log units) below what was measured, within the range that was stated.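

In this assay, 4-fluorophenoxy to 4-(trifluoromethyl)phenoxy gives a 1.5-fold lower number from compound 3 to compound 4 (0.17 log units; within the scatter) on this core, and the comparison with the earlier step on the other core reads: the same change on two cores in this assay, a 2.0-fold lower number (0.30 log units; within the scatter) from compound 2 to compound 1 and a 1.5-fold lower number (0.17 log units; within the scatter) from compound 3 to compound 4, 1.3-fold (0.13 log units) apart, within the scatter of two such steps. The two cores therefore give no sign that trifluoromethyl in place of fluoro behaves differently from one core to the other, and in that limited sense the change carries across. Neither step shows a real gain on its own, and two cores are too few to set a rule for the series.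

The compounds shown leave open whether another group at this place on the phenoxy ring, such as chloro, methoxy or nitrile, would move the number beyond the scatter. Also open, on these data alone, is whether a carboxylic acid or a longer chain in place of the aminopropoxy or guanidinopropoxy arm would lift these compounds out of the weak range they share.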